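Inverting a single stereocentre in compound 2

This account rests on a few compounds, and the source may have more. Where it says the series, first, only, none or still open, it means among the compounds named here.

Two measured compounds share one core, seen in compound 1 `COc1cc(NC(=O)c2ccc(C3CCCCC3)cc2)ccc1OC1CCN(C)C1` and compound 2 `COc1cc(NC(=O)c2ccc(C3CCCCC3)cc2)ccc1OC[C@H]1CCCN1C`. In an assay on HEK293 cells for displacement of a labelled ligand from melanin-concentrating hormone receptor 1 (Homo sapiens) (a lower number here means a stronger inhibitor, a higher number a weaker inhibitor), compound 1 gives 63.1 nM, and compound 2 gives 79.4 nM. Within the data shown here, the only measured step, a 1.3-fold higher number from compound 1 to compound 2 (0.10 log units; within the scatter), puts (1-methylpyrrolidin-2-yl)methyl in place of 1-methylpyrrolidin-3-yl on an oxygen on an aromatic ring. Compound 2 thus holds the higher of these two numbers only nominally, since its gap to compound 1 is within the scatter.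

Compound 3 `COc1cc(NC(=O)c2ccc(C3CCCCC3)cc2)ccc1OC[C@@H]1CCCN1C` differs from compound 2 by the two compounds have the same atoms and bonds and differ only in configuration as drawn: 1 of 1 stereo elements differ; a stereocentre at a saturated ring carbon is drawn R in compound 2 and S in compound 3. Among the measured compounds shown here, no measured step speaks to such an inversion; the one known step moved the ring's point of attachment rather than its handedness, and stayed within the scatter. For compound 3, the expectation is therefore a step of a 1.3-fold higher number from compound 2 to compound 3 (0.10 log units; within the scatter) in this assay, with a wide range allowing either direction. Compound 3 is expected to give 100 nM, between 25 nM and 500 nM.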

Compound 3, inhibition constant: 39.8 nM
Compound 3: the middle estimate sits 2.5-fold (0.40 log units) above what was measured; low and high end bracket the measured number.
By their numbers in this assay, from the lowest: compounds 3, 1 and 2 (each within the scatter of the next).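

Inverting the stereocentre at the saturated ring carbon is now measured directly, and in this assay it amounts to a 2.0-fold lower number from compound 2 to compound 3 (0.30 log units; within the scatter). On this oxygen, then, the R and S forms of the (1-methylpyrrolidin-2-yl)methyl group cannot be told apart by this measurement, and swapping in that group for 1-methylpyrrolidin-3-yl also stays inside the usual spread of repeats when the S form is used, at a 1.6-fold lower number from compound 1 to compound 3 (0.20 log units; within the scatter). The comparison of the R and S forms is a clean one, since only one feature can account for any gap between them: the fact that compounds 2 and 3 differ only in the configuration as drawn

Still open, on these data alone, is whether this oxygen accepts quite different groups, such as a chain ending in a carboxylic acid, a primary amine or a longer chain carrying the same amine. Also open, as far as these compounds go, is how the R and S forms would compare with the methyl group gone from the ring nitrogen.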